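Pyrrole for Chlorophenyl on a Thiosemicarbazone Core

The source may hold more compounds than are shown below. What is called first, only, known or untested is meant among the compounds shown, and "the series" means these compounds.

Compound 3 `CC1=CC[C@H](C(C)(C)NC(=S)N/N=C/c2ccccc2Cl)CC1` holds the lowest of the two plain numbers in a functional assay on PC-3 cells (Homo sapiens) for inhibition, read by sulforhodamine B assay, with a stated time of 48 h (on this read-out lower numbers stand for stronger inhibition of growth and higher numbers for weaker inhibition of growth), giving 700 nM. Compound 1 `CC1=CC[C@H](C(C)(C)NC(=S)N/N=C/c2ccccc2)CC1` gives 5700 nM in this assay. Compound 2 `CC1=CC[C@H](C(C)(C)NC(=S)N/N=C/c2ccc(F)cc2)CC1`, by contrast, reaches only a limit of this assay, < 900 nM, as noted by the limit of < 900 nM in this assay, at which 1 of the 3 values shown sits. Compound 4 `CC1=CC[C@H](C(C)(C)NC(=S)N/N=C/c2ccc[nH]2)CC1` differs from compound 3 by 1H-pyrrol-2-yl in place of 2-chlorophenyl on a carbon with a double bond to nitrogen. The step bearing most directly on this change is the one that introduced the chloro group: an 8.1-fold lower number from compound 1 to compound 3 (0.91 log units; beyond the scatter); the fluoro step, an at least 6.3-fold lower number from compound 1 to compound 2 (0.80 log units; beyond the scatter), points the same way. Removing the chloro group while also changing the ring is therefore expected to raise the number, so a 4.3-fold higher number from compound 3 to compound 4 (0.63 log units; beyond the scatter) is estimated for the step. Compound 4 is expected to give about 3000 nM, with a range from 800 nM to 12000 nM.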

Compound 4, concentration for total growth inhibition: > 100000 nM
Compound 4: no number, only a limit; the forecaster's own chance of this, stated with the estimate: 5%; middle value at least 33-fold (1.52 log units) away from the limit.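

Compound 4 gives no number in this assay, only a limit: the limit of > 100000 nM in this assay, at which 1 of the 4 values shown sits.

This position therefore tolerates a change of ring far less than the halogen steps suggested, since even the unsubstituted phenyl of compound 1 compares favourably, with an at least 17-fold higher number from compound 1 to compound 4 (1.24 log units; beyond the scatter). Against the halogenated rings, 1H-pyrrol-2-yl gives an at least 110-fold higher number from compound 2 to compound 4 (2.04 log units; beyond the scatter) and an at least 140-fold higher number from compound 3 to compound 4 (2.15 log units; beyond the scatter).

The compounds shown leave open whether the loss comes from the five-membered ring or from the pyrrole hydrogen. A furan-2-yl or a 1-methyl-1H-pyrrol-2-yl group at this place would separate the two.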